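Methylation of a Ring Amino Nitrogen and Kinetic Solubility

A few compounds are considered here, and "the series" means these few. Any claim that something is new, unique, unknown or untested is made for them only; others in the source may bear on it.

The study concerns four sulfonamides sharing a dichlorophenyl sulfonamide on a bicyclic core, examined in a physicochemical assay for solubility, read by chemiluminescence, measured as kinetic solubility; a higher number here means a more soluble compound, a lower number a less soluble compound. Compound 1 `COc1nn(CC(N)=O)c2ncnc(NS(=O)(=O)c3cccc(Cl)c3Cl)c12` carries a carbamoylmethyl group on the core. In this assay compound 1 gives >= 490000 nM, which is a limit of the assay and not a number. Compound 2 `CNC(=O)Cn1nc(OC)c2c(NS(=O)(=O)c3cccc(Cl)c3Cl)ncnc21` differs from compound 1 by methyl in place of hydrogen on an amide-type nitrogen. In this assay compound 2 likewise gives only a limit, >= 509000 nM. The step that the two limits leave unreadable from compound 1 to compound 2 therefore has no readable size, as both values rest on limits (the limit of >= 490000 nM in this assay, at which 1 of the 3 values shown sits, and (the limit of >= 509000 nM in this assay, at which 1 of the 3 values shown sits)).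

Compound 3 `COc1nn(C)c2nc(N)nc(NS(=O)(=O)c3cccc(Cl)c3Cl)c12` has a different core; the difference between the cores of compound 1 and compound 3 is not broken down here. In this assay compound 3 also gives a limit, >= 649000 nM (the limit of >= 649000 nM in this assay, at which 1 of the 3 values shown sits).

Compound 4 `CNc1nc(NS(=O)(=O)c2cccc(Cl)c2Cl)c2c(OC)nn(C)c2n1` has not been measured. It differs from compound 3 by methyl in place of hydrogen on a nitrogen on an aromatic ring. Within the data shown here, this is the same kind of change as the one from compound 1 to compound 2, but not the same: there the methyl entered on an amide-type nitrogen whose other neighbours are a carbonyl carbon, here on a nitrogen on an aromatic ring whose other neighbours are an aromatic carbon. The earlier step is unreadable, so no size carries over. Since compound 3 sits at the limit (the limit of >= 649000 nM in this assay, at which 1 of the 3 values shown sits), compound 4 is expected to stay highly soluble. The expected step is an at least 1.0-fold lower number from compound 3 to compound 4 (0.03 log units; that floor lies within the scatter). For compound 4 in this assay the estimate is 600000 nM, with a range from 200000 nM to 900000 nM, and the assay is expected most likely to report only a limit again.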

Compound 4, solubility: 376000 nM
Compound 4: middle estimate off by 1.6-fold (0.20 log units), on the high side; the measured number falls inside the stated range.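

Among these compounds, on the core of compound 3, methyl in place of hydrogen on a nitrogen on an aromatic ring gives an at least 1.7-fold lower number from compound 3 to compound 4 (0.23 log units; that floor lies within the scatter) in this assay, so this is the first reading of the change that carries any size, though only as a floor. As far as these compounds go, the true size of the step stays unknown because compound 3 rests on a limit of the assay and not on a number: the limit of >= 649000 nM in this assay, at which 1 of the 4 values shown sits. The step from compound 1 to compound 2 cannot be read, and there the methyl entered on an amide-type nitrogen and not on a nitrogen on an aromatic ring, so the series offers no two sizes to set side by side and shows neither that the change carries from one core to another nor that it fails to.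

The compounds shown leave open how an ethyl group or a longer chain in place of the methyl on that nitrogen would read in this assay on the core of compound 3. They also leave open how a cyclic amine such as morpholine in place of the methylamino group, or a carboxylic acid in place of the carbamoylmethyl group of compound 1, would read there.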